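Ether-linked aryl acid on a shared core

A few compounds are considered here, and "the series" means these few. Any claim that something is new, unique, unknown or untested is made for them only; others in the source may bear on it.

Measured compounds:
- compound 1, `Cc1ccccc1-n1nc(C)c2c1NC(=O)[C@H](C)S[C@@H]2c1ccc(-c2cccc(C(=O)O)c2)cc1`: "not active" (no number reported) in an assay on isolated protein for agonist activity at Bile acid receptor (Homo sapiens), read by AlphaScreen, with a stated time of 30 min; a higher number here means that more compound is needed for the effect, a lower number that less compound is needed
- compound 2, `Cc1ccccc1-n1nc(C)c2c1NC(=O)[C@H](C)S[C@@H]2c1ccc(-c2ccoc2)cc1`: 3500 nM
- compound 3, `COc1ccc(Oc2ccc([C@H]3S[C@@H](C)C(=O)Nc4c3c(C)nn4-c3ccccc3C)cc2)cc1`: 2200 nM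

Compound 3 gives one of the two numbers recorded in this assay. Its neighbour in the series, compound 2, differs from it only by 4-methoxyphenoxy in place of furan-3-yl on an aromatic carbon, and that step, a 1.6-fold lower number from compound 2 to compound 3 (0.20 log units; within the scatter), stays within the scatter, so the two numbers cannot be ordered. Compound 1, which carries a 3-carboxyphenyl directly on the aromatic carbon, gave no number at all in this assay.

Compound 4, `Cc1ccccc1-n1nc(C)c2c1NC(=O)[C@H](C)S[C@@H]2c1ccc(Oc2cccc(C(=O)O)c2)cc1`, is not yet measured. It differs from compound 3 by 3-carboxyphenyl in place of 4-methoxyphenyl on an oxygen on an aromatic ring. Within the data shown here, no measured step bears directly on this change. Among the measured compounds shown here, the only related information is that compound 1, whose 3-carboxyphenyl sits on the aromatic carbon without the oxygen, was reported as not active, whereas compound 3 with its 4-methoxyphenoxy gives a number; that makes a weaker result for compound 4 the more likely expectation. Compound 4 is therefore estimated at 7000 nM (range 1800 nM to 30000 nM), which would mean an expected step of a 3.2-fold higher number from compound 3 to compound 4 (0.50 log units; beyond the scatter).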

Compound 4, half-maximal effective concentration: "not active" (no number reported)
Compound 4 has no reported number here; no gap can be computed for the estimate.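

In this assay compound 4 gave "not active" (no number reported) and so offers no number to set against compound 3, and no step can be read. The compounds shown leave open whether any carboxyl-bearing aryl group on the shared core can give a number. No measurement shown here bears on this result.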